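A Smaller Chain Replaces a Ring-Bearing Group

This account rests on a few compounds, and the source may have more. Where it says the series, first, only, none or still open, it means among the compounds named here.

Compound 1, `COc1ccc(-c2nc(/N=C(\N)n3ccnc3)sc2-c2ccc(OC)cc2)cc1`, has been tested in a functional assay with Oryctolagus cuniculus as the target; a higher number here means a weaker inhibitor, a lower number a stronger inhibitor. For compound 1 only a limit of the assay is known, > 100 nM, and not a number. Compound 2, `COc1ccc(-c2nc(C(N)=O)sc2-c2ccc(OC)cc2)cc1`, shares the core of compound 1 but carries a different group on the aromatic carbon. In this assay compound 2 also gives only a limit, > 1000 nM. The step that the two limits leave unreadable from compound 1 to compound 2 cannot be read since the limit of > 100 nM in this assay, at which 1 of the 2 values shown sits, and the limit of > 1000 nM in this assay, at which 1 of the 2 values shown sits, hold both of its ends.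

Compound 3, `COc1ccc(-c2nc(C(=O)N=C(N)N)sc2-c2ccc(OC)cc2)cc1`, is not yet measured. It differs from compound 1 thus: a group of 6 heavy atoms (2 carbon, 3 nitrogen, 1 oxygen; no ring) in place of a group of 8 heavy atoms (4 carbon, 4 nitrogen; one five-membered aromatic ring with 2 hetero atoms), on an aromatic carbon. Among the compounds with values here, the one measured step, from compound 1 to compound 2, likewise put a group without a ring in place of the ring-bearing group, and its size stayed unreadable, so neither a size nor a direction can be taken from it. The change in compound 3 is of the same kind.

Compound 3 is therefore expected to remain weak in this assay, around 3000 nM, within 300 nM to 30000 nM. The step that the limit leaves unreadable from compound 1 to compound 3 is the expected size, with a fair chance that only a limit is reported again.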

Compound 3, half-maximal inhibitory concentration: > 100 nM
Compound 3 gave a limit, no number (the forecaster's own chance of this, stated with the estimate: 60%); the middle value does not contradict the limit.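

In this assay, compound 3, like compound 1 and compound 2, gives only a limit and not a number, so no step among these three compounds can be read: the limit of > 100 nM in this assay, at which 2 of the 3 values shown sit.

The compounds shown leave open how strongly each of them inhibits in this assay, and whether changing the group on the aromatic carbon alters that at all.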